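Chloro for fluoro on a benzotriazole series in rat liver microsomes

A few compounds are considered here, and "the series" means these few. Any claim that something is new, unique, unknown or untested is made for them only; others in the source may bear on it.

The measured compounds:
compound 1, `Fc1ccc(-c2ccc(Cn3nnc4ccccc43)cc2)c(Cl)c1`, 2.6 mL/min/g;
compound 2, `Clc1ccc(-c2ccc(Cn3nnc4ccccc43)cc2)c(Cl)c1`, 1.4 mL/min/g;
compound 3, `Fc1ccc(Cn2nnc3c(Br)cccc32)cc1`, 1 mL/min/g.

In an ADME assay on microsomes from liver (Rattus norvegicus, strain Wistar) for metabolic stability, tested at 2.5 uM (a higher number here means faster removal of the compound, a lower number slower removal), compound 1 gives 2.6 mL/min/g and compound 2 gives 1.4 mL/min/g. The change between them is chloro in place of fluoro on an aromatic carbon, and it made a step of a 1.9-fold lower number from compound 1 to compound 2 (0.27 log units; within the scatter). Compound 3 gives 1 mL/min/g; the difference between its core and that of compound 1 is not broken down here. Compound 4, `Clc1ccc(Cn2nnc3c(Br)cccc32)cc1`, has not been measured; it differs from compound 3 by chloro in place of fluoro on an aromatic carbon, the same kind of change, though here the place is not meta to a chloro group. Because the earlier step was a 1.9-fold lower number from compound 1 to compound 2 (0.27 log units; within the scatter), compound 4 is expected to give 0.8 mL/min/g, between 0.4 mL/min/g and 1.6 mL/min/g, a step of a 1.3-fold lower number from compound 3 to compound 4 (0.10 log units; within the scatter).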

Compound 4, intrinsic clearance in a liver preparation (reported as CLH), per the amount of preparation that the assay uses: 2.2 mL/min/g
Compound 4: the middle estimate sits 2.8-fold (0.44 log units) below what was measured; measured number above the stated range.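

Chloro in place of fluoro on an aromatic carbon gave a 2.2-fold higher number from compound 3 to compound 4 (0.34 log units; beyond the scatter) in this assay. Set beside the earlier step, this one does not match it, so what the change did on one core did not carry over to the other: the same change on two cores in this assay, a 1.9-fold lower number (0.27 log units; within the scatter) from compound 1 to compound 2 and a 2.2-fold higher number (0.34 log units; beyond the scatter) from compound 3 to compound 4, 4.1-fold (0.61 log units) apart, beyond the scatter of two such steps With only one pair on each core, this shows that the step cannot be transferred as it stands between these two cores, but it does not show which difference between the cores sets the two steps apart.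

The compounds shown leave open how the same change behaves on any further core. They also leave open how a nitrile or a methoxy group would fare in place of the halogen.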